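The source may hold more compounds than are shown below. What is called first, only, known or untested is meant among the compounds shown, and "the series" means these compounds.

In a functional assay on SMMC-7721 cells (Homo sapiens) for antiproliferative activity, read by MTT assay, with a stated time of 48 h (a lower number here means a stronger inhibitor, a higher number a weaker inhibitor), two esters built on a shared core have been measured so far. Compound 1 (`CC(C)=CCC[C@]1(C)/C=C/[C@@H](OC(=O)C(C)C)[C@](C)(O)/C=C/C(=O)/C(CO)=C\C1`) gives 10400 nM, and compound 2 (`CCCC(=O)O[C@@H]1/C=C/[C@@](C)(CCC=C(C)C)C/C=C(/CO)C(=O)/C=C/[C@@]1(C)O`) gives 7810 nM. Among the measured compounds shown here, the only measured step is a 1.3-fold lower number from compound 1 to compound 2 (0.12 log units; within the scatter), so compound 2 cannot be separated from the one compound it can be compared with. Compound 3 (`CC(C)=CCC[C@]1(C)/C=C/[C@@H](OC(=O)c2ccccc2)[C@](C)(O)/C=C/C(=O)/C(CO)=C\C1`) keeps the core but changes the same ester: phenyl in place of propyl on a carbonyl carbon. In words, this is phenyl in place of propyl on a carbonyl carbon, or propylcarbonyl to benzoyl.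

For the measured compounds named here, the measured step is the only evidence at this carbonyl carbon, and it is a weak guide. It replaced isopropyl with propyl, and neither of the two measured compounds has a ring at this place. The data therefore give no direction for the new change, and nothing beyond the scatter is expected in this assay. The expected change is a 1.0-fold lower number from compound 2 to compound 3 (0.02 log units; within the scatter), although the missing ring data call for a wide range. For compound 3 the estimated value is 7500 nM, with an expected range of 3000 nM to 18000 nM.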

Compound 3, half-maximal inhibitory concentration: 20300 nM
The estimate for compound 3 lay 2.7-fold (0.43 log units) below the measured number; the whole stated range lies below it.
By their numbers in this assay, from the lowest: compounds 2, 1 and 3 (each within the scatter of the next, the first and the last beyond it).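

In this assay, among the compounds shown here, compound 3 brings the first ring to this carbonyl carbon, and a 2.6-fold higher number from compound 2 to compound 3 (0.41 log units; beyond the scatter) is the first step here that clears the scatter, showing that the group at this place can matter, with phenyl on the side of the weaker inhibitor. The effect is small and depends on the comparison: a 2.0-fold higher number from compound 1 to compound 3 (0.29 log units; within the scatter), so phenyl is separated from propyl but not from isopropyl, and this ester cannot be placed apart from both chains. No evidence available here bears on what lies behind the step from propyl to phenyl.

A cyclohexyl group, which is a ring but not an aromatic one, and a longer chain such as hexyl would help show whether the higher number goes with the aromatic ring or simply with a larger group on this carbonyl carbon. On these data alone, it also remains open whether any group at this place, such as a phenyl ring carrying an amine or a carboxylic acid, could give a number clearly lower than those of compound 1 and compound 2.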